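Methoxy on the shared core: expected cytotoxicity

This account rests on a few compounds, and the source may have more. Where it says the series, first, only, none or still open, it means among the compounds named here.

In a functional assay on A549 cells (Homo sapiens) for cytotoxicity, with a stated time of 48 h (on this read-out lower numbers stand for stronger inhibition and higher numbers for weaker inhibition), compound 2 `C[S+]([O-])/C=C/c1cc(=O)c2ccccc2o1` gives 1900 nM. Compound 1 `Cc1ccc2c(=O)cc(/C=C/[S+](C)[O-])oc2c1` gives 2000 nM. Compound 3 `Cc1ccc2oc(/C=C/[S+](C)[O-])cc(=O)c2c1` gives 1700 nM. All three values lie within the scatter of each other, so compound 2 has no separate place among them.

Compound 4 `COc1ccc2c(=O)cc(/C=C/[S+](C)[O-])oc2c1` carries methoxy in place of hydrogen on an aromatic carbon.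

The nearest measured changes exchange methyl and hydrogen on an aromatic carbon: a 1.1-fold lower number from compound 1 to compound 2 (0.02 log units; within the scatter) and a 1.1-fold lower number from compound 2 to compound 3 (0.05 log units; within the scatter). Both stay within the scatter. Within the data shown here, no methoxy compound has been measured, so this support is indirect.

In this assay the expected result is a 1.1-fold lower number from compound 2 to compound 4 (0.02 log units; within the scatter), with no expected step beyond the scatter. The estimate for compound 4 is 1800 nM, with an expected range of 800 nM to 3800 nM.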

Compound 4, half-maximal inhibitory concentration: 2200 nM
Estimate against measurement, compound 4: 1.2-fold (0.09 log units) below, and the stated range covers the measured number.
By their numbers in this assay, from the lowest: compounds 3, 2, 1 and 4 (each within the scatter of the next).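

Methoxy at this aromatic carbon reads no differently from hydrogen or methyl in this assay, with a 1.2-fold higher number from compound 2 to compound 4 (0.06 log units; within the scatter) and a 1.1-fold higher number from compound 1 to compound 4 (0.04 log units; within the scatter). The flat picture seen with methyl therefore extends, across these four compounds, to a group with an oxygen and a hydrogen-bond acceptor. No evidence available here bears on this result.

Going by these compounds, whether an amine, a carboxylic acid or a longer alkoxy chain at this carbon would give a step beyond the scatter stays open. Also open, on these data alone, is how methoxy reads at the carbon that carries methyl in compound 3.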